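This account rests on a few compounds, and the source may have more. Where it says the series, first, only, none or still open, it means among the compounds named here.

Compound 2 `COc1cccc(-c2cc(COC(Cc3cn(C4CCN(Cc5ccc([N+](=O)[O-])cc5)CC4)nn3)c3ccc(Br)cc3)on2)c1` gives 5000 nM in a functional assay on Caco-2 cells (Homo sapiens) for cytotoxicity, with a stated time of 48 h (on this read-out lower numbers stand for stronger inhibition and higher numbers for weaker inhibition), the lowest of the two numbers shown so far. Compound 1 `O=[N+]([O-])c1ccc(CN2CCC(n3cc(CC(OCc4cc(-c5ccccc5)no4)c4ccc(Br)cc4)nn3)CC2)cc1` gives 7000 nM in this assay, and the step of a 1.4-fold lower number from compound 1 to compound 2 (0.15 log units; within the scatter). Compound 3 `N#Cc1cccc(-c2cc(COC(Cc3cn(C4CCN(Cc5ccc([N+](=O)[O-])cc5)CC4)nn3)c3ccc(Br)cc3)on2)c1` differs from compound 2 by cyano in place of methoxy on an aromatic carbon. Among the measured compounds shown here, the only measured step on that same aromatic carbon, the move from hydrogen to methoxy, stayed within the scatter, so this further swap is expected to bring no step beyond the scatter either, no change at the digits printed from compound 2 to compound 3 (within the scatter). Compound 3 is therefore estimated at 5000 nM, with a range from 2500 nM to 10000 nM.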

Compound 3, half-maximal inhibitory concentration: 3000 nM
Compound 3: the middle estimate sits 1.7-fold (0.22 log units) above what was measured; the range from low to high includes it.
By their numbers in this assay, from the lowest: compounds 3, 2 and 1 (each within the scatter of the next, the first and the last beyond it).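

Placing cyano where methoxy stood on this aromatic carbon gives a 1.7-fold lower number from compound 2 to compound 3 (0.22 log units; within the scatter), so this assay does not separate these two groups. Set against hydrogen, however, cyano gives a 2.3-fold lower number from compound 1 to compound 3 (0.37 log units; beyond the scatter), the first modest step at this position to pass beyond the scatter. Nothing available explains that step.

On these data alone, it remains open whether an amine, a carboxylic acid or a longer chain such as ethoxy on this carbon would shift the number further. Also open, as far as these compounds go, is whether cyano would give a similar step elsewhere on the same ring.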